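Chloro to methyl on the anilide ring of compound 2

The source may report more compounds than this note shows. Statements on the series, on what has been measured and on what is new or still open speak of the compounds shown alone.

Measured compounds:
compound 1, `CC(=O)c1ccc(NC(=O)/C=C/C(=O)N2C/C(=C\c3ccc([N+](=O)[O-])cc3)C(=O)/C(=C/c3ccc([N+](=O)[O-])cc3)C2)cc1`, 390 nM
compound 2, `O=C(/C=C/C(=O)N1C/C(=C\c2ccc([N+](=O)[O-])cc2)C(=O)/C(=C/c2ccc([N+](=O)[O-])cc2)C1)Nc1ccc(Cl)cc1`, 1200 nM
compound 3, `Cc1ccc(NC(=O)/C=C/C(=O)N2C/C(=C\c3ccccc3)C(=O)/C(=C/c3ccccc3)C2)cc1`, 660 nM

In a functional assay on Molt4/C8 cells (Homo sapiens) for cytotoxicity (on this read-out higher numbers stand for weaker inhibition and lower numbers for stronger inhibition), compound 2 gives the highest of the three numbers. Its separation from compound 1 is a 3.1-fold higher number from compound 1 to compound 2 (0.49 log units; beyond the scatter), beyond the scatter, whereas compound 3 gives 660 nM, a number within the scatter of that of compound 2, so no order between compounds 2 and 3 can be read. Compound 4, `Cc1ccc(NC(=O)/C=C/C(=O)N2C/C(=C\c3ccc([N+](=O)[O-])cc3)C(=O)/C(=C/c3ccc([N+](=O)[O-])cc3)C2)cc1`, differs from compound 2 by methyl in place of chloro on an aromatic carbon. Going by the values given here, the only measured step at this position is a 3.1-fold higher number from compound 1 to compound 2 (0.49 log units; beyond the scatter), which exchanged acetyl for chloro; no measured pair exchanges chloro for methyl, and compound 3, the only methyl-bearing compound, differs from compound 4 in its core as well. The expectation for compound 4 in this assay is therefore a step of a 1.4-fold lower number from compound 2 to compound 4 (0.15 log units; within the scatter), a slight lowering that stays within the scatter. Compound 4 is estimated at 850 nM, with a range of 350 nM to 2100 nM.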

Compound 4, half-maximal inhibitory concentration: 700 nM
Estimate against measurement, compound 4: 1.2-fold (0.08 log units) above, and the stated range covers the measured number.
By their numbers in this assay, from the lowest: compounds 1, 3, 4 and 2 (each within the scatter of the next, the first and the last beyond it).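

In this assay, methyl in place of chloro on the aromatic carbon gives a 1.7-fold lower number from compound 2 to compound 4 (0.23 log units; within the scatter), so no order can be read between these two groups. Methyl in place of acetyl gives a 1.8-fold higher number from compound 1 to compound 4 (0.25 log units; within the scatter), also within the scatter, whereas the earlier step of a 3.1-fold higher number from compound 1 to compound 2 (0.49 log units; beyond the scatter) lies beyond it. At this position, only acetyl and chloro are therefore separated, and methyl cannot be told apart from either of them; nothing given here accounts for these numbers.

The compounds shown leave open how an amine or a carboxylic acid on this aromatic carbon would read. They also leave open whether chloro and methyl would stay within the scatter of each other on the core of compound 3, which is shown only with methyl.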